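Adding Chloro to an Amide: Expected Solubility Shift

This account rests on a few compounds, and the source may have more. Where it says the series, first, only, none or still open, it means among the compounds named here.

Measured so far:
Compound 1 `Cc1cc(Br)ccc1C(=O)Nc1ccccn1` — in a physicochemical assay for solubility, read by nephelometry, measured as kinetic solubility, at pH 2, tested at 10 mg/mL (on this read-out higher numbers stand for higher solubility and lower numbers for lower solubility), compound 1 gives > 100 ug/mL, which is a limit of the assay rather than a number.
Compound 2 `Cc1c(F)cccc1C(=O)Nc1ccccn1` — in this assay compound 2 gives 50 ug/mL.
Compound 3 `Cc1ccccc1C(=O)Nc1cc(C#N)ccn1` — in this assay compound 3 gives 50 ug/mL.

Compound 2 sits level with compound 3 at the digits given, and the two values lie within the usual scatter of each other, so no order can be read between them. The value for compound 1 stands apart only as a limit (the limit of > 100 ug/mL in this assay, at which 1 of the 3 values shown sits), not as a number.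

Compound 4 `Cc1c(F)cccc1C(=O)Nc1cc(Cl)ccn1` has not yet been measured in this assay. It differs from compound 2 in one place: chloro in place of hydrogen on an aromatic carbon. Among the compounds with values here, no measured pair shows this exact change, so there is no recorded step to lean on. The expectation is a modest decrease in solubility, possibly no larger than the scatter, with the step of a 1.7-fold lower number from compound 2 to compound 4 (0.22 log units; within the scatter) estimated from compound 2. Compound 4 is therefore estimated to give 30 ug/mL, with a range from 12 ug/mL to 60 ug/mL.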

Compound 4, solubility: 12.5 ug/mL
Compound 4: middle estimate off by 2.4-fold (0.38 log units), on the high side; the measured number falls inside the stated range.
By their numbers in this assay, from the lowest: compound 4; then compounds 2 and 3 (each within the scatter of the next). At a limit, above all of these: compound 1.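

In this assay, chloro in place of hydrogen on this aromatic carbon, opposite the ring nitrogen, brings a 4.0-fold lower number from compound 2 to compound 4 (0.60 log units; beyond the scatter). This is the first change at a single place among the compounds shown, and it reveals that a substitution at this position can move the read-out by more than the usual scatter. Nothing shown explains the size of this step.

The compounds shown leave open whether another group at this position, such as an amine, a carboxylic acid or a methoxy group, would lower the number as chloro does, leave it unchanged or raise it. A single pair also cannot tell whether chloro would bring a similar step on another core, such as the core of compound 1, or at another aromatic carbon.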